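The source may report more compounds than this note shows. Statements on the series, on what has been measured and on what is new or still open speak of the compounds shown alone.

Compound 1 `C=CS(=O)(=O)N[C@@H]1CCN(S(=O)(=O)c2c(C(N)=O)[nH]c3ccc(Br)cc23)C1` and compound 2 `C=CC(=O)N[C@@H]1CCN(S(=O)(=O)c2c(C(N)=O)[nH]c3ccc(Br)cc23)C1` share a core and differ in one place: vinylsulfonyl in place of vinylcarbonyl on an amine nitrogen. In an ADME assay on MT4 cells (Homo sapiens) for cytotoxicity, read by MTT assay, with a stated time of 5 days (on this read-out higher numbers stand for lower toxicity in this test and lower numbers for higher toxicity in this test), compound 2 gives 178000 nM, whereas compound 1 gives 2100 nM. The step is an 85-fold lower number from compound 2 to compound 1 (1.93 log units; beyond the scatter).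

Compound 3 `C=CC(=O)NC1CCN(S(=O)(=O)c2c(C(N)=O)[nH]c3ccc(Br)cc23)CC1` carries the same vinylcarbonyl group as compound 2, but on a different core; the difference between the two cores is not broken down here. For compound 3 this assay gives only a limit, > 274000 nM, and this is the limit at which (the limit of > 274000 nM in this assay, at which 1 of the 3 values shown sits).

Compound 4 `C=CS(=O)(=O)NC1CCN(S(=O)(=O)c2c(C(N)=O)[nH]c3ccc(Br)cc23)CC1` is not yet measured in this assay. It stands to compound 3 as compound 1 stands to compound 2: vinylsulfonyl in place of vinylcarbonyl on an amine nitrogen. The place is described in the same words for both pairs, so this is the same change, made a second time.

Within the data shown here, the expected outcome rests on the one measured instance of the change, the step from compound 2 to compound 1, where the number fell by a large amount in this assay. Since compound 3 has only a limit, the starting point is uncertain, and the expected step is accordingly wide. The step from compound 3 to compound 4 is estimated at an at least 68-fold lower number from compound 3 to compound 4 (1.83 log units; beyond the scatter). Compound 4 is therefore expected to give about 4000 nM in this assay, with a range estimated from 1000 nM to 40000 nM.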

Compound 4, half-maximal cytotoxic concentration: 6500 nM
Beside the measured number, compound 4's estimate is 1.6-fold (0.21 log units) below it; low and high end bracket the measured number.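

Putting vinylsulfonyl in place of vinylcarbonyl on an amine nitrogen lowers the number in this assay on both cores shown, and on the second core the result is an at least 42-fold lower number from compound 3 to compound 4 (1.62 log units; beyond the scatter), so the direction seen on the core of compound 2 carries over to the core of compound 3. For compound 3 the value of > 274000 nM is a limit and not a number, so the new step gives a lower bound on its size and not the size itself. This shows that the change is large on both cores, but not that it is equally large on each, and two cores cannot establish a rule for the whole series: the same change on two cores in this assay, an 85-fold lower number (1.93 log units; beyond the scatter) from compound 2 to compound 1 and an at least 42-fold lower number (1.62 log units; beyond the scatter) from compound 3 to compound 4; the limit leaves it open whether they differ.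

The compounds shown leave open whether the lower numbers go with the sulfonyl part or with the vinyl part of the new group, a question that an ethylsulfonyl group and a propanoyl group on the same amine nitrogen would address. They also leave open whether the change holds on a further core, for example one carrying chlorine in place of the bromine.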